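Bromo on the hydroxyphenyl of compound 3

The source may hold more compounds than are shown below. What is called first, only, known or untested is meant among the compounds shown, and "the series" means these compounds.

In a functional assay on MCF7 cells (Homo sapiens) for cytotoxicity, read by MTT assay, with a stated time of 48 h (a higher number here means a weaker inhibitor, a lower number a stronger inhibitor), compound 1 `COc1ccc(/C=N/NC(=O)CSc2nnc(-c3ccncc3)o2)cc1` gives 17600 nM, compound 2 `COc1cccc(/C=N/NC(=O)CSc2nnc(-c3ccncc3)o2)c1` gives 13800 nM and compound 3 `O=C(CSc1nnc(-c2ccncc2)o1)N/N=C/c1ccccc1O` gives 4750 nM. Compound 3 stands lowest of the three, with a 3.7-fold lower number from compound 1 to compound 3 (0.57 log units; beyond the scatter) and a 2.9-fold lower number from compound 2 to compound 3 (0.46 log units; beyond the scatter), while a 1.3-fold lower number from compound 1 to compound 2 (0.11 log units; within the scatter). Compound 4 `O=C(CSc1nnc(-c2ccncc2)o1)N/N=C/c1cc(Br)ccc1O` differs from compound 3 by bromo in place of hydrogen on an aromatic carbon. Among the compounds with values here, all three measured steps exchange the whole aryl substituent on the carbon with a double bond to nitrogen; none of them adds a substituent to a retained 2-hydroxyphenyl, so no measured step bears directly on this change. Within the data shown here, the only guidance is that compound 3 already holds the lowest number and that the measured steps were at most modest. A step of no more than modest size in this assay is therefore expected, with the direction open. For compound 4 the expected value is 3500 nM, with a range from 1200 nM to 10000 nM. The step expected is a 1.4-fold lower number from compound 3 to compound 4 (0.13 log units; within the scatter).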

Compound 4, half-maximal inhibitory concentration: 7770 nM
Compound 4: the middle estimate sits 2.2-fold (0.35 log units) below what was measured; low and high end bracket the measured number.
By their numbers in this assay, from the lowest: compounds 3, 4, 2 and 1 (each within the scatter of the next, the first and the last beyond it).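

In this assay, within the data shown here, the 5-bromo-2-hydroxyphenyl group gives the first look at a substituent added to a retained 2-hydroxyphenyl, on the aromatic carbon para to the hydroxy group, and the step is a 1.6-fold higher number from compound 3 to compound 4 (0.21 log units; within the scatter) so bromo at this place leaves no change that can be told from the scatter. Against the methoxyphenyl compounds the result divides: a 1.8-fold lower number from compound 2 to compound 4 (0.25 log units; within the scatter) stands inside the scatter while a 2.3-fold lower number from compound 1 to compound 4 (0.36 log units; beyond the scatter) stands beyond it, so the separation that compound 3 holds from both methoxyphenyl compounds carries over to compound 4 only against the 4-methoxyphenyl one. No evidence on hand accounts for this step.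

From the compounds shown here alone, whether the outcome is particular to bromo stays open, and a chloro, methyl, amine or carboxylic acid group on the same carbon would test that. Also open, going by these compounds, is whether the hydroxy group still matters once bromo is present.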